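Anilide substituent swap and mouse liver microsomal clearance

This account rests on a few compounds, and the source may have more. Where it says the series, first, only, none or still open, it means among the compounds named here.

Compound 1 `CC(C)c1ccc(NC(=O)[C@H]2CN(C)C[C@@H]2c2ccc(/C=C/C(=O)Nc3ccccc3N)cc2)cc1` stands highest of the three numbers in an in vitro ADME assay on microsomes from liver (Mus musculus) for pharmacokinetics, read by LC-MS, with a stated time of 10 min, tested at 1 uM (on this read-out higher numbers stand for fast clearance and lower numbers for slow clearance), where compound 1 gives 54 mL/min/kg. In this assay compound 2 `CN1C[C@H](C(=O)Nc2ccc(C(F)(F)F)cc2)[C@@H](c2ccc(/C=C/C(=O)Nc3ccccc3N)cc2)C1` gives 23 mL/min/kg and compound 3 `CN1C[C@H](C(=O)Nc2ccc(Br)cc2)[C@@H](c2ccc(/C=C/C(=O)Nc3ccccc3N)cc2)C1` gives 16 mL/min/kg; the steps are a 2.3-fold lower number from compound 1 to compound 2 (0.37 log units; beyond the scatter) and a 3.4-fold lower number from compound 1 to compound 3 (0.53 log units; beyond the scatter), while a 1.4-fold lower number from compound 2 to compound 3 (0.16 log units; within the scatter) stays within the scatter. Compound 4 `Cc1cc(NC(=O)[C@H]2CN(C)C[C@@H]2c2ccc(/C=C/C(=O)Nc3ccccc3N)cc2)ccc1Cl` differs from compound 1 as 4-chloro-3-methylphenyl in place of 4-isopropylphenyl on an amide-type nitrogen. For the measured compounds named here, both measured steps away from compound 1 put trifluoromethyl or bromo in place of isopropyl and gave modest drops, so a drop of similar size is expected here; the methyl entering alongside chloro has no measured counterpart, which widens the range. Compound 4 is therefore estimated at 25 mL/min/kg, between 12 mL/min/kg and 50 mL/min/kg, an expected step of a 2.2-fold lower number from compound 1 to compound 4 (0.33 log units; beyond the scatter).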

Compound 4, clearance: 65 mL/min/kg
Estimate against measurement, compound 4: 2.6-fold (0.41 log units) below, and the stated range ends below it.
By their numbers in this assay, from the lowest: compounds 3 and 2 (each within the scatter of the next); then compounds 1 and 4 (each within the scatter of the next).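

In this assay the drop seen with the earlier replacements of isopropyl does not carry over to 4-chloro-3-methylphenyl on the amide-type nitrogen (a 1.2-fold higher number from compound 1 to compound 4 (0.08 log units; within the scatter)). For the compounds shown here, this place therefore separates the anilides more widely than the earlier compounds showed (a 4.1-fold higher number from compound 3 to compound 4 (0.61 log units; beyond the scatter)) and (a 2.8-fold higher number from compound 2 to compound 4 (0.45 log units; beyond the scatter)), so replacing 4-isopropylphenyl does not by itself lower clearance. No supporting data bear on this result.

On these data alone, whether chloro or the added methyl sets this level remains open. A 4-chlorophenyl or 3-methylphenyl group at this place would separate the two.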